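Solubility notes: benzyl variation on the shared core

This account rests on a few compounds, and the source may have more. Where it says the series, first, only, none or still open, it means among the compounds named here.

Measured so far in a physicochemical assay for solubility, using the shake flask method, in simulated intestinal fluid, measured as kinetic solubility, with a stated time of 2 h, at 25 degrees C, at pH 6.5; a higher number here means a more soluble compound, a lower number a less soluble compound:
- compound 1 `Cc1nc(C(=O)O)c(N)c2c1C(=O)N(Cc1ccccc1)C2=O` gives 177000 nM
- compound 2 `Cc1nc(C(=O)N(C)C)c(N)c2c1C(=O)N(Cc1ccccc1)C2=O` gives 172000 nM
- compound 3 `Cc1noc(-c2nc(C)c3c(c2N)C(=O)N(Cc2ccc(F)cc2)C3=O)n1` gives < 5000 nM

The value for compound 3 in this assay is a limit of the assay, not a number (the limit of < 5000 nM in this assay, at which 1 of the 3 values shown sits). For the measured compounds named here, the one measured step, a 1.0-fold lower number from compound 1 to compound 2 (0.01 log units; within the scatter), concerns the acid-to-amide change on the carbonyl carbon and lies within the scatter. Going by the values given here, no measured step touches the benzyl group on the amide-type nitrogen in the ring, so nothing measured bears directly on the change now considered.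

Compound 4 `Cc1noc(-c2nc(C)c3c(c2N)C(=O)N(Cc2ccccc2Cl)C3=O)n1` differs from compound 3 only there: 2-chlorophenyl in place of 4-fluorophenyl on a saturated chain carbon bound to an amide-type nitrogen in a ring. Among the compounds with values here, with no measured step on this part of the shared core, and with compound 3 standing at a limit, the expectation is that compound 4 will also sit at or near that limit in this assay, with no step beyond the scatter expected; the step estimated is a step that the limit leaves unreadable from compound 3 to compound 4. For compound 4 the estimated solubility in this assay is therefore 3000 nM, within 500 nM to 10000 nM, and it is expected that the assay again reports only a limit.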

Compound 4, solubility: < 5000 nM
Compound 4: no number, only a limit; the forecaster's own chance of this, stated with the estimate: 70%; the middle value is on the limit's open side.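

In this assay, compound 3 and compound 4 both sit at a limit of the assay rather than at a number, so no step can be read between them: the limit of < 5000 nM in this assay, at which 2 of the 4 values shown sit.

Left open is what size, if any, the change from 4-fluorobenzyl to 2-chlorobenzyl has in this assay.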